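The compounds below may be only part of what the source reports. "The series", "measured", "known", "first", "only" and "open" are said of these compounds alone.

Measured in an ADME assay on A549 cells (Homo sapiens) for cytotoxicity, read by CellTiter-Glo; a lower number here means that less compound is tolerated, a higher number that more compound is tolerated:

Compound 1 `Cc1cc(=O)oc2cc(OCC(O)CN3CCC(C(N)=O)CC3)ccc12` — > 100000 nM; this is a limit of the assay, not a number.
Compound 2 `Cc1c(Cc2ccc(F)cc2)c(=O)oc2cc(OCC(O)CN3CCC(C(N)=O)CC3)ccc12` — 89300 nM.
Compound 3 `Cc1c(Cc2cccc(F)c2)c(=O)oc2cc(OCC(O)CN3CCC(C(N)=O)CC3)ccc12` — 53300 nM.

Compound 3 holds the lowest of the two numbers in this assay; its nearest neighbour is compound 2, with a 1.7-fold lower number from compound 2 to compound 3 (0.22 log units; within the scatter), a gap within the scatter. The remaining value, for compound 1, is only a limit (the limit of > 100000 nM in this assay, at which 1 of the 3 values shown sits).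

Compound 4 `Cc1c(Cc2ccc(Cl)cc2)c(=O)oc2cc(OCC(O)CN3CCC(C(N)=O)CC3)ccc12` is not yet measured. It differs from compound 3 by 4-chlorophenyl in place of 3-fluorophenyl on a saturated chain carbon bound to an aromatic carbon.

The measured steps that bear on this are the two benzyl attachments, an at least 1.1-fold lower number from compound 1 to compound 2 (0.04 log units; that floor lies within the scatter) and an at least 1.8-fold lower number from compound 1 to compound 3 (0.27 log units; that floor lies within the scatter), both floors that sit within the scatter, and the halogen shift between the two benzyl isomers, a 1.7-fold lower number from compound 2 to compound 3 (0.22 log units; within the scatter), again within the scatter. For the measured compounds named here, no measured pair exchanges fluorine for chlorine, so that part of the change has no precedent here. The expectation for this assay is therefore a step of a 1.1-fold higher number from compound 3 to compound 4 (0.05 log units; within the scatter) from compound 3 to compound 4, which is not beyond the scatter. Compound 4 is estimated at 60000 nM, with a range from 30000 nM to 120000 nM.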

Compound 4, half-maximal cytotoxic concentration: 40000 nM
Compound 4: the middle estimate sits 1.5-fold (0.18 log units) above what was measured, within the range that was stated.
By their numbers in this assay, from the lowest: compounds 4, 3 and 2 (each within the scatter of the next, the first and the last beyond it). At a limit, above all of these: compound 1.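

In this assay, for the compounds shown here, chloro in place of fluoro on an aromatic carbon gives the first step between two benzyl compounds that lies beyond the scatter (a 2.2-fold lower number from compound 2 to compound 4 (0.35 log units; beyond the scatter)), while the change from 3-fluorobenzyl to 4-chlorobenzyl stays within it (a 1.3-fold lower number from compound 3 to compound 4 (0.12 log units; within the scatter)), so compound 3 and compound 4 cannot be ordered. The 4-chlorobenzyl group is also the first attachment to the core of compound 1 whose floor lies beyond the scatter (an at least 2.5-fold lower number from compound 1 to compound 4 (0.39 log units; beyond the scatter)). The value of compound 1 is a limit and not a number: the limit of > 100000 nM in this assay, at which 1 of the 4 values shown sits.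

On these data alone, whether a 3-chlorobenzyl group would read with compound 4 or with compound 3 stays open. So does the outcome of replacing the halogen with a methoxy, a nitrile or a carboxylic acid.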